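The source may hold more compounds than are shown below. What is called first, only, known or untested is meant among the compounds shown, and "the series" means these compounds.

Measured so far:
compound 1 `CC1CCN(C2CCN(S(=O)(=O)c3cccnc3Cl)CC2)CC1` – > 5000 nM
compound 2 `COC(=O)c1ccc(S(=O)(=O)N2CCC(N3CCC(C)CC3)CC2)cc1` – > 5000 nM
compound 3 `C#CCCC(=O)CC1CCN(C2CCN(S(=O)(=O)c3c(C)cc(C)cc3C)CC2)CC1` – 3 nM

In a functional assay on DLD-1 cells (Homo sapiens) for antiproliferative activity, read by CellTiter-Glo, with a stated time of 72 h (a higher number here means a weaker inhibitor, a lower number a stronger inhibitor), compound 2 gives only a limit of the assay, > 5000 nM, not a number. Compound 1 likewise returns only a limit, > 5000 nM. Compound 3, which carries the pentynone chain on the shared core, gives 3 nM. Compound 2 thus sits at the limit of > 5000 nM in this assay, at which 2 of the 3 values shown sit, far from compound 3.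

Compound 4 `CC1CCN(C2CCN(S(=O)(=O)c3ccc(OC(F)(F)F)cc3)CC2)CC1` is not yet measured. It differs from compound 2 by trifluoromethoxy in place of methoxycarbonyl on an aromatic carbon. Compound 4, like compound 2, lacks the chain that compound 3 carries, and nothing measured here separates the two ring substituents. In this assay the expected step is a step that the limit leaves unreadable from compound 2 to compound 4, none beyond the scatter. Compound 4 is estimated at 6000 nM, between 1500 nM and 25000 nM, most likely again reported only as a limit.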

Compound 4, half-maximal inhibitory concentration: 16 nM
Beside the measured number, compound 4's estimate is 380-fold (2.57 log units) above it; measured number outside the range, below it.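

In this assay, trifluoromethoxy in place of methoxycarbonyl on the aromatic carbon para to a large group gives an at least 310-fold lower number from compound 2 to compound 4 (2.49 log units; beyond the scatter). Compound 4 carries no pentynone chain, so a number well clear of the limit does not depend on that chain. The full size of the step cannot be read, because compound 2 gives only a limit: the limit of > 5000 nM in this assay, at which 2 of the 4 values shown sit.

As far as these compounds go, what a methoxy or trifluoromethyl group gives at this place stays open. Also open, from the compounds shown here alone, is whether the pentynone chain and trifluoromethoxy together give a lower number than either alone.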